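The source may hold more compounds than are shown below. What is called first, only, known or untested is meant among the compounds shown, and "the series" means these compounds.

Three compounds sharing one core were examined in a functional assay on MCF7 cells (Homo sapiens) for inhibition, read by MTT assay, with a stated time of 48 h, tested at 10 uM; on this read-out higher numbers stand for more inhibition at the one concentration tested (going by the name of the read-out) and lower numbers for less inhibition. Compound 1 `COc1cc2cc(NC(C)=O)c(=O)oc2cc1OCCOc1no[n+]([O-])c1S(=O)(=O)c1ccccc1` gives 83.7% in this assay. Compound 3 `COc1cc2cc(N)c(=O)oc2cc1OCCOc1no[n+]([O-])c1S(=O)(=O)c1ccccc1` differs from compound 1 by hydrogen in place of acetyl on a nitrogen on an aromatic ring; in this assay compound 3 gives 88.6%, and the step is a number 4.9 percentage points higher from compound 1 to compound 3 (within the scatter). Compound 2 `COc1cc2cc(NC(C)=O)c(=O)oc2cc1OCCCCOc1no[n+]([O-])c1S(=O)(=O)c1ccccc1` keeps the acetamido group of compound 1 but differs from it in the rest of the core, and that difference between the two cores is not broken down here. In this assay compound 2 gives 80.4%, a value within the scatter of both compound 1 and compound 3, so no order among the three can be read from these numbers.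

Compound 4 `COc1cc2cc(N)c(=O)oc2cc1OCCCCOc1no[n+]([O-])c1S(=O)(=O)c1ccccc1` has not yet been measured. It differs from compound 2 by hydrogen in place of acetyl on a nitrogen on an aromatic ring, and the surroundings of the place are described in the same words as for the pair compound 1 and compound 3, so this is the same change, seen twice among these compounds. Within the data shown here, the expected step for compound 4 is a number 4.6 percentage points higher from compound 2 to compound 4 (within the scatter) in this assay, set beside the earlier step, and it rests on the single observation that this change moved a number 4.9 percentage points higher from compound 1 to compound 3 (within the scatter), a movement that stayed within the scatter. Compound 4 is therefore estimated to give about 85% in this assay, with the expected range running from 75% to 93%.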

Compound 4, a percentage reported as inhibition, at one concentration (the size of the read-out at that concentration, not a potency): 89%
Beside the measured number, compound 4's estimate is 4 percentage points below it; the range from low to high includes it.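

With hydrogen in place of acetyl on a nitrogen on an aromatic ring, this assay gives a number 8.6 percentage points higher from compound 2 to compound 4 (within the scatter). Set beside the earlier step, the same change shows no difference between the two cores that this read-out can resolve: the same change on two cores in this assay, a number 4.9 percentage points higher (within the scatter) from compound 1 to compound 3 and a number 8.6 percentage points higher (within the scatter) from compound 2 to compound 4, 3.7 percentage points apart, within the scatter of two such steps

Both steps point the same way, but each lies within the scatter, so the two pairs show only that no dependence on the core appears here; they do not show that the change moves the read-out at all, nor that it would behave alike on any other core.

The compounds shown carry only the acetamido and amino groups at that nitrogen, so it remains open what a benzoyl group, a larger acyl group or a methylamino group would give there. Going by these compounds, it also remains open how the same change would behave on a core carrying a longer chain, and a reading at one concentration leaves the potency of all these compounds undefined.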